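This account rests on a few compounds, and the source may have more. Where it says the series, first, only, none or still open, it means among the compounds named here.

Measured compounds:
Compound 1 `COc1ccc(Cn2cc(CNC(=O)c3cn(-c4ccccc4)nc3-c3ccccc3)nn2)cc1OC` gives 10800 nM in a functional assay on HeLa cells (Homo sapiens) for antiproliferative activity, read by sulforhodamine B assay, with a stated time of 48 h; on this read-out higher numbers stand for weaker inhibition of growth and lower numbers for stronger inhibition of growth.
Compound 2 `COc1cc(Cn2cc(CNC(=O)c3cn(-c4ccccc4)nc3-c3ccccc3)nn2)cc(OC)c1` gives 12200 nM in this assay.

Of these two numbers, compound 1's is the lower, yet the step of a 1.1-fold higher number from compound 1 to compound 2 (0.05 log units; within the scatter) lies within the scatter, so no order is claimed. Compound 3 `COc1ccc(Cn2cc(CNC(=O)c3cn(-c4ccccc4)nc3-c3ccc(Cl)cc3)nn2)cc1OC` differs from compound 1 by chloro in place of hydrogen on an aromatic carbon. Among the compounds with values here, the only measured step concerns the dimethoxyphenyl and not this aromatic carbon, so no measured step bears directly on the change. In this assay compound 3 is therefore expected to show no step beyond the scatter, a 1.1-fold lower number from compound 1 to compound 3 (0.03 log units; within the scatter), with an estimate of 10000 nM and a range of 4000 nM to 25000 nM.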

Compound 3, concentration for 50% growth inhibition: 200 nM
Compound 3: the middle estimate sits 50-fold (1.70 log units) above what was measured, and the stated range ends above it.
By their numbers in this assay, from the lowest: compound 3; then compounds 1 and 2 (each within the scatter of the next).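

Within the data shown here, compound 3 shows that the phenyl of the shared core, unchanged in the earlier compounds, responds strongly to substitution: the single chlorine para to a large group gives a 54-fold lower number from compound 1 to compound 3 (1.73 log units; beyond the scatter) in this assay. The earlier step on the dimethoxyphenyl stayed within the scatter, so this aromatic carbon is the first place shown where one change moves the number substantially. Nothing available here accounts for the size of this step.

The compounds shown leave open whether fluoro, bromo, methoxy or an amine at this carbon would give a similar step. They also leave open whether chloro would act in the same way alongside the 3,5-dimethoxyphenyl of compound 2.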